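This account rests on a few compounds, and the source may have more. Where it says the series, first, only, none or still open, it means among the compounds named here.

Of the compounds shown here, two sharing one core have been measured in an assay on CHO-K1 cells for displacement of a labelled ligand from prostaglandin E2 receptor EP1 subtype (Homo sapiens); on this read-out lower numbers stand for stronger inhibition and higher numbers for weaker inhibition. Compound 1 `Cc1cc(NC(=O)c2ccccc2)nn1Cc1cc(Cl)ccc1OCc1ccccc1` carries a benzamide on that core, and in this assay compound 1 gives 15.9 nM. Compound 2 `Cc1cc(NC(=O)OCc2ccccn2)nn1Cc1cc(Cl)ccc1OCc1ccccc1` carries a carbamate instead, and compound 2 gives 79.4 nM. Of the two numbers seen so far, compound 2 holds the higher one, separated from compound 1 by a 5.0-fold higher number from compound 1 to compound 2 (0.70 log units; beyond the scatter), a step that lies beyond the scatter of repeated measurements.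

Compound 3 `COC(=O)Nc1cc(C)n(Cc2cc(Cl)ccc2OCc2ccccc2)n1` has not yet been measured. It differs from compound 2 in one place: hydrogen in place of pyridin-2-yl on a saturated chain carbon bound to an oxygen next to a carbonyl group. Within the data shown here, the only measured step that touches this region is a 5.0-fold higher number from compound 1 to compound 2 (0.70 log units; beyond the scatter), which swapped the whole group on the carbonyl carbon rather than trimming the carbamate, so it serves only as a loose guide. Among the measured compounds shown here, with no closer precedent, the step from compound 2 to compound 3 is expected to be a 1.3-fold higher number from compound 2 to compound 3 (0.10 log units; within the scatter), small enough that it may stay within the scatter in either direction. Compound 3 is therefore estimated at 100 nM, within a range from 25 nM to 400 nM.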

Compound 3, half-maximal inhibitory concentration: 200 nM
Beside the measured number, compound 3's estimate is 2.0-fold (0.30 log units) below it; measured number inside the range.
By their numbers in this assay, from the lowest: compound 1; then compound 2; then compound 3.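

Going from (pyridin-2-yl)methoxy to methoxy in this assay gives a 2.5-fold higher number from compound 2 to compound 3 (0.40 log units; beyond the scatter), so a step within the carbamate series now shows that removing the pyridin-2-yl ring from the saturated chain carbon weakens inhibition, which the earlier comparison of a benzamide with a carbamate could not isolate. Placing methoxy instead of phenyl on the carbonyl carbon gives a 13-fold higher number from compound 1 to compound 3 (1.10 log units; beyond the scatter), a large step that puts the three groups on this carbon in a clear order: phenyl gives the lowest number, (pyridin-2-yl)methoxy the middle one and methoxy the highest. Nothing measured here explains why the numbers move this way.

A benzyloxy group on the carbonyl carbon would help show whether the ring itself or its nitrogen matters, and the compounds shown do not settle that point. They also leave open whether an ethoxy or a longer chain would recover part of the loss seen with methoxy, or whether a ring is needed.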